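The compounds below may be only part of what the source reports. "The series", "measured", "known", "first", "only" and "open" are said of these compounds alone.

Compound 2, `CN(C)c1nc(N)nc2c1ncn2/C=C1/CC1(CO)CO`, was assessed in an ADME assay on CCRF-HSB-2 cells (Homo sapiens) for cytotoxicity, with a stated time of 7 days (on this read-out higher numbers stand for lower toxicity in this test and lower numbers for higher toxicity in this test), and compound 2 gives only a limit of the assay, > 20000 nM. Its neighbour compound 1, `CNc1nc(N)nc2c1ncn2/C=C1/CC1(CO)CO`, carries a hydrogen where compound 2 carries a methyl on a ring nitrogen; compound 1 likewise gives only a limit in this assay, > 20000 nM. The step that the two limits leave unreadable from compound 1 to compound 2 is therefore not readable, since (the limit of > 20000 nM in this assay, at which 2 of the 2 values shown sit). Compound 3, `Nc1nc(NC2CC2)c2ncn(/C=C3/CC3(CO)CO)c2n1`, is the next member: cyclopropylamino in place of dimethylamino on an aromatic carbon. For the measured compounds named here, the only measured step bearing on this change is the unreadable one from compound 1 to compound 2, so the size of the step in this assay cannot be foreseen from the numbers; the estimated step of a number no higher from compound 2 to compound 3 (the limit leaves the size open) is expected to stay within the scatter, most likely ending again at the limit. Compound 3 is thus expected to give about 20000 nM, in a range from 8000 nM to 40000 nM.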

Compound 3, half-maximal cytotoxic concentration: > 20000 nM
Compound 3: no number, only a limit; the forecaster's own chance of this, stated with the estimate: 80%; the middle value sits exactly at the limit.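

For the compounds shown here, compound 3 gives only a limit, as compound 1 and compound 2 do, so no new step among them can be read in this assay: the limit of > 20000 nM in this assay, at which 3 of the 3 values shown sit. The compounds shown leave open whether these three differ in cytotoxicity at all, and by how much.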